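A few compounds are considered here, and "the series" means these few. Any claim that something is new, unique, unknown or untested is made for them only; others in the source may bear on it.

Working notes on the series. Compound 1 `CCCn1cnc2c(NCc3ccccc3)ncnc21` gives 29100 nM in an assay on CHO cells for displacement of a labelled ligand from transmembrane domain-containing protein TMIGD3 (Homo sapiens); a higher number here means a weaker inhibitor, a lower number a stronger inhibitor. Within the data shown here, compound 2 `CCCn1c(Br)nc2c(NCc3ccccc3)ncnc21` gives 11100 nM in this assay, the lowest of the two numbers so far; the only nearby change, a 2.6-fold lower number from compound 1 to compound 2 (0.42 log units; beyond the scatter), is the sole measured step bearing on the next one. Compound 3 `CCCn1c(-c2ccco2)nc2c(NCc3ccccc3)ncnc21` differs from compound 2 by furan-2-yl in place of bromo on an aromatic carbon. Among the measured compounds shown here, no measured step replaces bromo with a larger ring, so the expectation rests on compound 2 alone and is uncertain. Compound 3 is therefore estimated at 8000 nM (range 2500 nM to 25000 nM), which means an expected step of a 1.4-fold lower number from compound 2 to compound 3 (0.14 log units; within the scatter), likely within the scatter.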

Compound 3, inhibition constant: 402 nM
Compound 3: the middle estimate sits 20-fold (1.30 log units) above what was measured, outside the stated range (below it).
By their numbers in this assay, from the lowest: compound 3; then compound 2; then compound 1.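

At this carbon, between two ring nitrogen atoms, the size of the effect depends strongly on the group: in this assay furan-2-yl gives a gain far larger than bromo did (a 28-fold lower number from compound 2 to compound 3 (1.44 log units; beyond the scatter)). Measured against the unsubstituted compound, the gain from furan-2-yl (a 72-fold lower number from compound 1 to compound 3 (1.86 log units; beyond the scatter)) also far exceeds that from bromo (a 2.6-fold lower number from compound 1 to compound 2 (0.42 log units; beyond the scatter)). Nothing available accounts for this gain.

Going by these compounds, whether it depends on the ring oxygen remains open, as thiophen-2-yl and phenyl would test. So does whether it persists with a butyl chain in place of propyl.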